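From ethoxy to isobutoxy in a cytotoxicity assay

The compounds below may be only part of what the source reports. "The series", "measured", "known", "first", "only" and "open" are said of these compounds alone.

Compound 1 (`CCOc1cc(-c2ccccc2)nc2ccccc12`) was tested in a functional assay on L1210 (1565) cells (Mus musculus) for cytotoxicity (a lower number here means that less compound is needed, a higher number that more compound is needed for the effect), where compound 1 gives > 10 ug/mL. This value is a limit of the assay and not a number. Compound 2 (`Oc1cc(-c2ccccc2)nc2c(O)cccc12`) gives > 10 ug/mL in this assay, which is likewise a limit. Compound 1 thus stands with the whole measured set at the limit of > 10 ug/mL in this assay, at which 2 of the 2 values shown sit.

Compound 3 (`CC(C)COc1cc(-c2ccccc2)nc2ccccc12`) keeps the core of compound 1 but carries isopropyl in place of methyl on a saturated chain carbon bound to an oxygen on an aromatic ring, which turns ethoxy into isobutoxy. Within the data shown here, no measured pair shows what such a change does in this assay, so no clear direction is expected, and another limit is likely. The expected change is a step that the limit leaves unreadable from compound 1 to compound 3, none beyond the scatter. Compound 3 is estimated at 12 ug/mL, with an expected range from 4 ug/mL to 30 ug/mL.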

Compound 3, half-maximal effective concentration: > 10 ug/mL
Compound 3: no number, only a limit; the forecaster's own chance of this, stated with the estimate: 65%; the middle value is on the limit's open side.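

The step from compound 1 to compound 3 cannot be read, since neither compound gives a number in this assay, only a limit: the limit of > 10 ug/mL in this assay, at which 3 of the 3 values shown sit.

The compounds shown leave open whether isobutoxy or ethoxy on the shared core differs at all in this assay, and what would give a readable number there.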